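The source may report more compounds than this note shows. Statements on the series, on what has been measured and on what is new or still open speak of the compounds shown alone.

Values in a functional assay on MCF7 cells (Homo sapiens) for antiproliferative activity, read by MTT assay, with a stated time of 48 h; on this read-out lower numbers stand for stronger inhibition and higher numbers for weaker inhibition:
- compound 1 `O=C(CN1CCCC1)Nc1ccc2ncnc(Nc3cccc(C(F)(F)F)c3)c2c1`: > 100000 nM (a limit)
- compound 2 `O=C(CN1CCCC1)Nc1ccc2ncnc(Nc3cccc(Cl)c3)c2c1`: > 100000 nM (a limit)
- compound 3 `O=C(CN1CCCC1)Nc1ccc2ncnc(Nc3cccc(Br)c3)c2c1`: 12000 nM

Going by the values given here, compound 3 gives 12000 nM, the only true number so far. The rest of the series shows (the limit of > 100000 nM in this assay, at which 2 of the 3 values shown sit).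

Compound 4 `O=C(CN1CCCC1)Nc1ccc2ncnc(Nc3ccc(Br)cc3)c2c1` is the next case, with the difference 4-bromophenyl in place of 3-bromophenyl on a nitrogen on an aromatic ring.

Among the compounds with values here, two measured steps bear on this: an at least 8.3-fold lower number from compound 1 to compound 3 (0.92 log units; beyond the scatter) and an at least 8.3-fold lower number from compound 2 to compound 3 (0.92 log units; beyond the scatter). Both exchange the group on an aromatic carbon and neither moves it, so they guide the estimate only indirectly. They do show that one small exchange separates a true number from a limit here. The third step, a step that the two limits leave unreadable from compound 1 to compound 2, adds nothing.

The change expected in this assay is a modest rise in the number, possibly reaching the limit, estimated as a 2.3-fold higher number from compound 3 to compound 4 (0.37 log units; beyond the scatter).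

For compound 4 the expected value is 28000 nM, with an estimated range of 7000 nM to 100000 nM.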

Compound 4, half-maximal inhibitory concentration: > 100000 nM
Compound 4: no number, only a limit; the forecaster's own chance of this, stated with the estimate: 35%; at least 3.5-fold (0.55 log units) between middle value and limit.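

Moving the bromo group with the atoms unchanged, 4-bromophenyl in place of 3-bromophenyl on a nitrogen on an aromatic ring, gives in this assay a step of its own: an at least 8.3-fold higher number from compound 3 to compound 4 (0.92 log units; beyond the scatter) shows that the place of the group matters as well as its identity, which the earlier exchanges of one group for another could not show. Compound 4 gives > 100000 nM as a limit and not a number. The steps from compound 1 and compound 2 to compound 4 cannot be read, and compound 3 remains the only compound with a true number: the limit of > 100000 nM in this assay, at which 3 of the 4 values shown sit.

Going by these compounds, how far the true value of compound 4 lies past its limit stays open. Also open, on these data alone, is whether an iodo or a methoxy group in place of the bromo of compound 3, or a longer chain on the amide carbonyl, would give a true number.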